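This account rests on a few compounds, and the source may have more. Where it says the series, first, only, none or still open, it means among the compounds named here.

Measured in a physicochemical assay for lipophilicity, read by mass spectrometry; on this read-out lower numbers stand for lower lipophilicity and higher numbers for higher lipophilicity:
compound 1 `COc1ccc(NC(=O)C2Cc3cc(OC)c(OC)cc3C2=O)cc1`: 2.08
compound 2 `COc1cc2c(cc1OC)C(=O)C(C(=O)Nc1ccc(Br)cc1)C2`: 3.03
compound 3 `CCOc1ccccc1NC(=O)C1Cc2cc(OC)c(OC)cc2C1=O`: 2.42

In this assay compound 3, at 2.42, stands second highest of the three. Compound 1 lies lower at 2.08 and compound 2 higher at 3.03, both gaps beyond the scatter.

The next step leads to compound 4 `COc1cc2c(cc1OC)C(=O)C(C(=O)Nc1ccccc1Br)C2`, with bromo in place of ethoxy on an aromatic carbon, ortho to a large group: bromo in place of ethoxy on an aromatic carbon.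

Within the data shown here, one measured step bears on this change: a number 0.95 log units higher from compound 1 to compound 2 (beyond the scatter), a modest rise with bromo in place of methoxy on an aromatic carbon. Among the measured compounds shown here, that step left methoxy rather than ethoxy, and no measured step changes a group ortho to a large group, so it is only a rough guide. Compound 1 gives 2.08 and compound 3 gives 2.42, so compound 3 already starts from the higher number and a smaller rise in this assay is expected. The expected change is a number 0.53 log units higher from compound 3 to compound 4 (beyond the scatter). For compound 4 the estimated value is 2.95, with an expected range from 2.6 to 3.3.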

Compound 4, partition coefficient: 3.03
The estimate for compound 4 lay 0.08 log units below the measured number; the measured number falls inside the stated range.
By their numbers in this assay, from the lowest: compound 1; then compound 3; then compounds 2 and 4 (each within the scatter of the next).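

In this assay bromo in place of ethoxy, ortho to a large group, brought a number 0.61 log units higher from compound 3 to compound 4 (beyond the scatter) and so showed a rise at this position, where the earlier step had only bromo in place of methoxy on the other side of the comparison. With 2-bromophenyl in place of 4-bromophenyl the result was no change at the digits printed from compound 2 to compound 4 (within the scatter), which means that for this pair the place of the bromo made no difference beyond the scatter, while 2-bromophenyl in place of 4-methoxyphenyl brought a number 0.95 log units higher from compound 1 to compound 4 (beyond the scatter) as a step of modest size. No measurement shown here explains these steps.

On these data alone, whether an amine, a carboxylic acid or a longer chain at this position would follow the same course remains open. So does whether the near match of the two bromo compounds holds for groups other than bromo.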